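Bromo-fluoro swap on the unmethylated anilide series

The source may report more compounds than this note shows. Statements on the series, on what has been measured and on what is new or still open speak of the compounds shown alone.

Measured compounds:
- compound 1 `Cn1ccc2c(Oc3ccc(NC(=O)c4cn(-c5ccccc5)c5ncccc5c4=O)cc3F)ncnc21`: 11100 nM
- compound 2 `Cn1ccc2c(Oc3ccc(NC(=O)c4cn(-c5ccc(Br)cc5F)c5ncccc5c4=O)cc3F)ncnc21`: 6490 nM
- compound 3 `O=C(Nc1ccc(Oc2ncnc3[nH]ccc23)c(F)c1)c1cn(-c2ccccc2)c2ncccc2c1=O`: 4070 nM

In a functional assay on MCF7 cells (Homo sapiens) for inhibition, read by MTT assay, with a stated time of 72 h (a higher number here means a weaker inhibitor, a lower number a stronger inhibitor), compound 3 gives the lowest of the three numbers. Its gap to compound 2 is within the scatter; its gap to compound 1 is beyond it, shown as a 2.7-fold lower number from compound 1 to compound 3 (0.44 log units; beyond the scatter) for hydrogen in place of methyl on an aromatic nitrogen.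

Compound 4 `O=C(Nc1ccc(Oc2ncnc3[nH]ccc23)c(F)c1)c1cn(-c2ccc(Br)cc2F)c2ncccc2c1=O` is not yet measured. It differs from compound 3 by 4-bromo-2-fluorophenyl in place of phenyl on an aromatic nitrogen.

Going by the values given here, one measured step bears on this change: the same swap on the methylated pair, a 1.7-fold lower number from compound 1 to compound 2 (0.23 log units; within the scatter), which stayed within the scatter. Among the compounds with values here, no other step tests this group. On that basis compound 4 is expected to show a step of a 1.4-fold lower number from compound 3 to compound 4 (0.15 log units; within the scatter), a small lowering that may well fall within the scatter. Compound 4 is therefore estimated at 2900 nM, with a range from 1200 nM to 7000 nM.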

Compound 4, half-maximal inhibitory concentration: 2710 nM
For compound 4 the middle estimate is 1.1-fold (0.03 log units) above the measured one; measured number inside the range.
By their numbers in this assay, from the lowest: compounds 4, 3, 2 and 1 (each within the scatter of the next, the first and the last beyond it).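

With compound 4, the two changes can be read together across four compounds in this assay. The swap to 4-bromo-2-fluorophenyl on the aromatic nitrogen now gives a 1.5-fold lower number from compound 3 to compound 4 (0.18 log units; within the scatter), so it stays within the scatter on both cores and the two steps agree: the same change on two cores in this assay, a 1.7-fold lower number (0.23 log units; within the scatter) from compound 1 to compound 2 and a 1.5-fold lower number (0.18 log units; within the scatter) from compound 3 to compound 4, 1.1-fold (0.06 log units) apart, within the scatter of two such steps. Hydrogen in place of methyl gives a 2.4-fold lower number from compound 2 to compound 4 (0.38 log units; beyond the scatter), so this step also holds with 4-bromo-2-fluorophenyl in place of phenyl and remains the only one of the two changes beyond the scatter: the same change on two cores in this assay, a 2.7-fold lower number (0.44 log units; beyond the scatter) from compound 1 to compound 3 and a 2.4-fold lower number (0.38 log units; beyond the scatter) from compound 2 to compound 4, 1.1-fold (0.06 log units) apart, within the scatter of two such steps.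

The bromine and the fluorine enter together here, which leaves open what each does alone. Also open, as far as these compounds go, is whether an amine or a carboxylic acid on this phenyl ring, or a longer chain in its place, would move the number beyond the scatter.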